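The source may hold more compounds than are shown below. What is called first, only, known or untested is meant among the compounds shown, and "the series" means these compounds.

Compound 1 `Cc1cc([C@@H]2[C@@H](C(=O)N=C(N)N)C2(C)C)ccc1F` and compound 2 `CC1(C)[C@H](C(=O)N=C(N)N)[C@H]1c1cc(Cl)ccc1Cl` share a core, and both have been tested in a functional assay on AP1 cells with sodium/hydrogen exchanger 1 (Homo sapiens) as the target; a higher number here means a weaker inhibitor, a lower number a stronger inhibitor. In this assay, for the measured compounds named here, compound 1 gives 32 nM, the higher of the two numbers known here. In this assay compound 2 gives 5 nM, and the gap between these two lies beyond the usual scatter, so compound 1 is the weaker inhibitor of the pair. Compound 3 `CCc1cc([C@@H]2[C@@H](C(=O)N=C(N)N)C2(C)C)ccc1F` has not yet been measured. It differs from compound 1 in one place: methyl in place of hydrogen on a saturated chain carbon bound to an aromatic carbon. Going by the values given here, no measured pair shows a step of this kind, so nothing about its effect can be read from the numbers available. A change this small is expected to move the result little, if at all, beyond the scatter, and the expected step is a 1.3-fold higher number from compound 1 to compound 3 (0.10 log units; within the scatter). Compound 3 is expected to give an estimated 40 nM, and its result is expected to lie between 15 nM and 110 nM.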

Compound 3, half-maximal inhibitory concentration: 5 nM
The estimate for compound 3 lay 8.0-fold (0.90 log units) above the measured number; measured number outside the range, below it.
By their numbers in this assay, from the lowest: compounds 2 and 3 (each within the scatter of the next); then compound 1.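

In this assay, a single added methyl on a saturated chain carbon bound to an aromatic carbon, which turns the methyl of compound 1 into the ethyl of compound 3, gives a 6.4-fold lower number from compound 1 to compound 3 (0.81 log units; beyond the scatter). This position therefore responds to a very small change: one extra carbon moves the number beyond the scatter, and in this one pair the longer group goes with the stronger inhibitor. No measurement available here explains this step.

A propyl group, a longer chain or an amine at this carbon would show whether the number keeps falling or turns back. One pair also leaves open whether this step would be similar on a compound with other groups elsewhere, such as the two chlorines of compound 2.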